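The source may report more compounds than this note shows. Statements on the series, on what has been measured and on what is new or still open speak of the compounds shown alone.

In a functional assay on A549 cells (Homo sapiens) for inhibition, read by MTT assay, with a stated time of 48 h (a higher number here means a weaker inhibitor of growth, a lower number a stronger inhibitor of growth), compound 2 `COc1ccc2c(c1)c(C1CC(c3ccc(Br)cc3)=NN1C(=O)c1ccc(OC)nc1)cn2C` gives > 10000 nM, which is a limit of the assay and not a number. Compound 1 `COc1ccc2c(c1)c(C1CC(c3ccccc3)=NN1C(=O)c1ccc(OC)nc1)cn2C`, which lacks the bromo group, gives 1110 nM in this assay. Among the measured compounds shown here, the only measured step is an at least 9.0-fold higher number from compound 1 to compound 2 (0.95 log units; beyond the scatter), for bromo in place of hydrogen on an aromatic carbon. Compound 3 `COc1ccc2c(c1)c(C1CC(c3cc(OC)c(OC)c(OC)c3)=NN1C(=O)c1ccc(OC)nc1)cn2C` has 3,4,5-trimethoxyphenyl in place of 4-bromophenyl on a carbon with a double bond to nitrogen. This change also removes the bromo group, so the measured step suggests a move back towards compound 1, of similar size and to a lower number. For the measured compounds named here, no measured step shows what the three methoxy groups do, so the expectation stays wide. The estimate implies an expected at least 5.0-fold lower number from compound 2 to compound 3 (0.69 log units; beyond the scatter). For compound 3, the estimated value is 2000 nM, with an expected range of 300 nM to 10000 nM.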

Compound 3, concentration for 50% growth inhibition: > 10000 nM
Compound 3 was reported as a limit; the forecaster's own chance of this, stated with the estimate: 20%; middle value at least 5.0-fold (0.69 log units) from the limit.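

In this assay compound 3 gives > 10000 nM, which is a limit of the assay and not a number. Replacing phenyl with 3,4,5-trimethoxyphenyl on the carbon with a double bond to nitrogen gives an at least 9.0-fold higher number from compound 1 to compound 3 (0.95 log units; beyond the scatter), so a step away from compound 1 at this position is not confined to the bromo group: two different substituted phenyl groups now share that direction. Compound 2 and compound 3 cannot be ordered, and the step between them cannot be read, because both stand at the same limit: the limit of > 10000 nM in this assay, at which 2 of the 3 values shown sit.

The compounds shown leave open whether any substituted phenyl at this position keeps a readable value, for instance one bearing a single fluoro or an amine. They also leave open whether the loss depends on the number of groups added to the phenyl ring or on their identity.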